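A few compounds are considered here, and "the series" means these few. Any claim that something is new, unique, unknown or untested is made for them only; others in the source may bear on it.

Measured so far in a toxicity assay on MT4 cells (Homo sapiens) for cytotoxicity, read by MTT assay; a higher number here means that more compound is tolerated, a lower number that less compound is tolerated:

compound 1 `Cc1cc(-c2ccccc2)cc(C)c1Oc1cc(N)nc(Nc2ccc(C#N)cc2)n1`: 25600 nM
compound 2 `Cc1cc(-c2cccc(F)c2)cc(C)c1Oc1cc(N)nc(Nc2ccc(C#N)cc2)n1`: 24700 nM
compound 3 `Cc1cc(-c2ccc(C#N)cc2)cc(C)c1Oc1cc(N)nc(Nc2ccc(C#N)cc2)n1`: 18100 nM

All three values of compound 1, compound 2 and compound 3 lie within the scatter of one another, so no ordering is claimed among them; the steps of a 1.4-fold lower number from compound 1 to compound 3 (0.15 log units; within the scatter) and a 1.4-fold lower number from compound 2 to compound 3 (0.14 log units; within the scatter) are within the scatter.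

Compound 4 `Cc1cc(-c2ccc(C#N)c(F)c2)cc(C)c1Oc1cc(N)nc(Nc2ccc(C#N)cc2)n1` is not yet measured. It differs from compound 3 by fluoro in place of hydrogen on an aromatic carbon. The same kind of change, made once before, is fluoro in place of hydrogen on an aromatic carbon, which gave a 1.0-fold lower number from compound 1 to compound 2 (0.02 log units; within the scatter). The two places are not identical: in compound 4 the fluoro sits ortho to a cyano group, which is absent in compound 2. The two cores differ by cyano in place of hydrogen on an aromatic carbon.

Resting on compound 2 and its step of a 1.0-fold lower number from compound 1 to compound 2 (0.02 log units; within the scatter), a step of about a 1.0-fold lower number from compound 3 to compound 4 (0.01 log units; within the scatter) is expected, and compound 4 is estimated at 17500 nM (range 9000 nM to 35000 nM).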

Compound 4, half-maximal cytotoxic concentration: 5000 nM
The estimate for compound 4 lay 3.5-fold (0.54 log units) above the measured number; measured number outside the range, below it.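

In this assay, fluoro in place of hydrogen does not carry over unchanged from one core to the other, giving a 3.6-fold lower number from compound 3 to compound 4 (0.56 log units; beyond the scatter) where the ring bears a cyano group: the same change on two cores in this assay, a 1.0-fold lower number (0.02 log units; within the scatter) from compound 1 to compound 2 and a 3.6-fold lower number (0.56 log units; beyond the scatter) from compound 3 to compound 4, 3.5-fold (0.54 log units) apart, beyond the scatter of two such steps

Read the other way, cyano in place of hydrogen also depends on the core, giving a 4.9-fold lower number from compound 2 to compound 4 (0.69 log units; beyond the scatter) where the ring bears a fluoro: the same change on two cores in this assay, a 1.4-fold lower number (0.15 log units; within the scatter) from compound 1 to compound 3 and a 4.9-fold lower number (0.69 log units; beyond the scatter) from compound 2 to compound 4, 3.5-fold (0.54 log units) apart, beyond the scatter of two such steps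

Both changes together give a 5.1-fold lower number from compound 1 to compound 4 (0.71 log units; beyond the scatter), so the two groups do not act independently in this pair, but a single pair on a single ring shows no cause and no general rule for the series.

Open, on these data alone, is whether the lower number requires the fluoro to sit ortho to a cyano group. Also open, as far as these compounds go, is whether a chloro or methoxy group in the same place would behave alike.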